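This account rests on a few compounds, and the source may have more. Where it says the series, first, only, none or still open, it means among the compounds named here.

Measured in a functional assay on HCT-116 cells (Homo sapiens) for cytotoxicity, read by MTT assay, with a stated time of 48 h; on this read-out higher numbers stand for weaker inhibition of growth and lower numbers for stronger inhibition of growth:
- Compound 1 `Cn1c(C(F)(F)F)nc2cc(Cl)c(Cl)cc21`: 56000 nM
- Compound 2 `CCn1c(C(F)(F)F)nc2cc(Cl)c(Cl)cc21`: 95300 nM

Going by the values given here, compound 2 stands within the scatter of compound 1, the only other measured compound. Compound 3 `CC(C)n1c(C(F)(F)F)nc2cc(Cl)c(Cl)cc21` differs from compound 2 by methyl in place of hydrogen on a saturated chain carbon bound to an aromatic nitrogen and a saturated chain carbon (ethyl to isopropyl). Among the compounds with values here, one measured step bears on this, a similar replacement that gave a 1.7-fold higher number from compound 1 to compound 2 (0.23 log units; within the scatter). The estimated change is a 1.2-fold higher number from compound 2 to compound 3 (0.06 log units; within the scatter), so no step beyond the scatter is expected in this assay. For compound 3 the expected value is 110000 nM, with an estimated range of 50000 nM to 240000 nM.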

Compound 3, concentration for 50% growth inhibition: 81900 nM
Estimate against measurement, compound 3: 1.3-fold (0.13 log units) above; low and high end bracket the measured number.
By their numbers in this assay, from the lowest: compounds 1, 3 and 2 (each within the scatter of the next).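

In this assay, the change from ethyl to isopropyl gives a 1.2-fold lower number from compound 2 to compound 3 (0.07 log units; within the scatter), a second step within the scatter on this aromatic nitrogen. Across the series, isopropyl in place of methyl gives a 1.5-fold higher number from compound 1 to compound 3 (0.17 log units; within the scatter), also within the scatter, so methyl, ethyl and isopropyl are not separated on this read-out. No other measurement is available to explain these numbers.

Still open, as far as these compounds go, is whether a longer chain, a benzyl group, or a chain carrying an amine or a carboxylic acid on this nitrogen would give a step beyond the scatter. Also open, from the compounds shown here alone, is how changes to the trifluoromethyl group would read.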